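Allyloxycarbonyl in place of carboxymethyl on a shared core

A few compounds are considered here, and "the series" means these few. Any claim that something is new, unique, unknown or untested is made for them only; others in the source may bear on it.

Compound 1 (`C#CCOC1=CC(=O)S[C@]1(C)CCCCCC`), compound 2 (`CCCCCCCC[C@@]1(C)SC(=O)C=C1OCC(=O)O`), compound 3 (`CCCCCC[C@@]1(C)SC(=O)C=C1OCC(=O)NCC(=O)OC`) and compound 4 (`C=CCOC(=O)OC1=CC(=O)S[C@]1(C)CCCCCCCC`) share one core. In a functional assay on MCF7 cells (Homo sapiens) for inhibition (on this read-out higher numbers stand for weaker inhibition and lower numbers for stronger inhibition), compound 1 gives 21.9 ug/mL and compound 2 gives 13.8 ug/mL while compound 3 gives 9.8 ug/mL in the same read-out. Compound 2 therefore lies within the scatter of both compound 1 and compound 3.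

Compound 4, not yet measured, differs from compound 2 by a single change (allyloxycarbonyl in place of carboxymethyl on an oxygen on an unsaturated carbon): allyloxycarbonyl in place of carboxymethyl on an oxygen on an unsaturated carbon. Going by the values given here, no two measured compounds differ in one place, so no measured step speaks directly to this change. Compound 3 at 9.8 ug/mL and compound 1 at 21.9 ug/mL mark the span seen so far with other chains and other groups on that oxygen, and compound 2 at 13.8 ug/mL is the starting point for the estimate. In this assay the expected 1.2-fold lower number from compound 2 to compound 4 (0.06 log units; within the scatter) stays within the scatter, with no firm direction. For compound 4 the estimate is 12 ug/mL with an expected range from 5 ug/mL to 28 ug/mL in this read-out.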

Compound 4, half-maximal inhibitory concentration: 14.2 ug/mL
Estimate against measurement, compound 4: 1.2-fold (0.07 log units) below; the measured number falls inside the stated range.
By their numbers in this assay, from the lowest: compounds 3, 2, 4 and 1 (each within the scatter of the next, the first and the last beyond it).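

In this assay, going by these compounds alone, the first step between two compounds that differ in one place is a 1.0-fold higher number from compound 2 to compound 4 (0.01 log units; within the scatter), so allyloxycarbonyl and carboxymethyl on an oxygen on an unsaturated carbon cannot be told apart on this read-out. The exchange takes away the hydrogen-bond donor of carboxymethyl, puts 6 heavy atoms in place of 4 and adds a second double bond outside aromatic rings, yet the step stays within the scatter. Nothing measured here explains why the two groups read alike.

The compounds shown leave open whether an amine or a free hydroxyl on the unsaturated carbon would also read within the scatter of compound 2. They also leave open what a longer chain on the shared core would do with either group held in place.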